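The source may report more compounds than this note shows. Statements on the series, on what has been measured and on what is new or still open speak of the compounds shown alone.

Working notes on the series. Compound 1 `COc1cc2ncnc(Nc3cccc(Cl)c3)c2cc1OCCCCC(=O)Nc1ccc(S(N)(=O)=O)cc1` and compound 2 `NS(=O)(=O)c1ccc(NC(=S)Nc2ccc3ncnc(Nc4cccc(C(F)(F)F)c4)c3c2)cc1` share an anilino-substituted core carrying a sulfonamide-bearing phenyl tail. In a functional assay on A-431 cells (Homo sapiens) for antiproliferative activity, read by MTT assay, with a stated time of 72 h (a lower number here means a stronger inhibitor, a higher number a weaker inhibitor), compound 1 gives 30400 nM. In this assay compound 2 gives 21700 nM, and the gap between compound 2 and compound 1 lies within the scatter, so no order between the two can be read from these figures. Compound 3 `Cc1cccc(Nc2ncnc3ccc(NC(=S)Nc4ccc(S(N)(=O)=O)cc4)cc23)c1` is the next member; the change from compound 2 is methyl in place of trifluoromethyl on an aromatic carbon, with the thiourea linker and the sulfonamide tail unchanged. Among the compounds with values here, no step between measured compounds exists here that would show what such a change does. For compound 3 in this assay the expectation is a step of a 1.1-fold lower number from compound 2 to compound 3 (0.04 log units; within the scatter) from compound 2, that is, no change beyond the scatter. For compound 3 the estimated value is 20000 nM, with a range from 8000 nM to 60000 nM.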

Compound 3, half-maximal inhibitory concentration: 23800 nM
Beside the measured number, compound 3's estimate is 1.2-fold (0.08 log units) below it, within the range that was stated.
By their numbers in this assay, from the lowest: compounds 2, 3 and 1 (each within the scatter of the next).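

Within the data shown here, the first step that isolates one place is the exchange of trifluoromethyl for methyl on an aromatic carbon, meta to a large group: in this assay it gives a 1.1-fold higher number from compound 2 to compound 3 (0.04 log units; within the scatter). With the thiourea linker and the sulfonamide tail held constant, going from 3-(trifluoromethyl)phenyl to 3-methylphenyl, and so from four heavy atoms to one, leaves the read-out within the scatter, and this pair gives no order between the two groups. Nothing available here bears on what lies behind this result.

Going by these compounds, whether an amine or a carboxylic acid on that aromatic carbon would shift the number beyond the scatter stays open. Also open, on these data alone, is whether the same exchange would behave alike with a linker other than the thiourea, such as the longer chain of compound 1.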